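Chloro-to-methyl swap on the anilide ring, second core

A few compounds are considered here, and "the series" means these few. Any claim that something is new, unique, unknown or untested is made for them only; others in the source may bear on it.

Working notes on a small set of thiosemicarbazone-linked oxindoles tested in a functional assay on CCRF-CEM cells (Homo sapiens), with a stated time of 72 h; a lower number here means a stronger inhibitor, a higher number a weaker inhibitor.

Compound 1, `O=C1Nc2cc(Cl)c(F)cc2/C1=N/NC(=S)Nc1ccc(Cl)cc1`, gives 48000 nM in this assay. Compound 2, `Cc1ccc(NC(=S)N/N=C2\C(=O)Nc3cc(Cl)c(F)cc32)cc1`, carries the change methyl in place of chloro on an aromatic carbon relative to compound 1; in this assay compound 2 gives 132000 nM. The measured step is a 2.8-fold higher number from compound 1 to compound 2 (0.44 log units; beyond the scatter).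

Compound 3, `O=C1/C(=N\NC(=S)Nc2ccc(Cl)cc2)c2cc(F)ccc2N1Cc1ccc(F)cc1`, is built on a second core; how the core of compound 3 differs from the core of compound 1 is not broken down here. In this assay compound 3 gives 56000 nM, which sits within the usual scatter of the value of compound 1, so no order between compound 1 and compound 3 is read from these numbers.

Compound 4, `Cc1ccc(NC(=S)N/N=C2\C(=O)N(Cc3ccc(F)cc3)c3ccc(F)cc32)cc1`, has not been measured. Within the data shown here, it differs from compound 3 by methyl in place of chloro on an aromatic carbon, the same change as the one from compound 1 to compound 2, made at the same kind of place on the ring.

The expectation for compound 4 rests on a single precedent: because the step of a 2.8-fold higher number from compound 1 to compound 2 (0.44 log units; beyond the scatter) was modest but beyond the scatter, the corresponding step on the second core is estimated at a 2.7-fold higher number from compound 3 to compound 4 (0.43 log units; beyond the scatter). Among the measured compounds shown here, with only one prior example of this change, and on a different core, the estimate is held loosely. Compound 4 is therefore expected to give about 150000 nM in this assay, with a likely range from 70000 nM to 320000 nM.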

Compound 4, half-maximal inhibitory concentration: 2500 nM
Beside the measured number, compound 4's estimate is 60-fold (1.78 log units) above it; measured number below the stated range.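

On the core of compound 3, methyl in place of chloro gives a 22-fold lower number from compound 3 to compound 4 (1.35 log units; beyond the scatter) in this assay, whereas on the core of compound 1 the same change gives a 2.8-fold higher number from compound 1 to compound 2 (0.44 log units; beyond the scatter). The change therefore does not carry over from one core to the other in this series, in either size or direction, and a step read on one core gave no usable guide to the other: the same change on two cores in this assay, a 2.8-fold higher number (0.44 log units; beyond the scatter) from compound 1 to compound 2 and a 22-fold lower number (1.35 log units; beyond the scatter) from compound 3 to compound 4, 62-fold (1.79 log units) apart, beyond the scatter of two such steps. This shows that the effect of the swap depends on the core it is made on, but with a single pair on each core, and with the two cores differing in more than one place, it does not show which feature of the cores goes with the reversal, why it arises, or how it would play out on a further core.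

Open, on these data alone, is whether the large step on the core of compound 3 is particular to methyl, or whether an ethyl group, a methoxy group or an amine in the same place would follow compound 4 or stay with compound 3. Also open, as far as these compounds go, is whether the same reversal appears in any cell line other than the one tested here.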